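Methoxy position shift on the dienone aryl end

This account rests on a few compounds, and the source may have more. Where it says the series, first, only, none or still open, it means among the compounds named here.

Of the compounds shown here, three have been measured so far. Compound 1 `COc1ccccc1/C=C/C(=O)/C=C/c1ccc(OCc2cn(CCOc3cc(=O)oc4ccccc34)nn2)c(OC)c1` gives 9490 nM in a functional assay on HCT-116 cells (Homo sapiens) for cytotoxicity, read by sulforhodamine B assay, with a stated time of 48 h (on this read-out lower numbers stand for stronger inhibition and higher numbers for weaker inhibition), and carries the highest of the three numbers, though compound 2 `COc1cc(/C=C/C(=O)/C=C/c2cc(OC)c(OC)c(OC)c2)ccc1OCc1cn(CCCOc2cc(=O)oc3ccccc23)nn1` with 8650 nM and compound 3 `COc1cc(/C=C/C(=O)/C=C/c2cccc3ccccc23)ccc1OCc1cn(CCOc2cc(=O)oc3ccccc23)nn1` with 6540 nM both lie within the scatter of it, so no order among the three can be read. Within the data shown here, the only step between two compounds differing in one place, a 1.5-fold lower number from compound 1 to compound 3 (0.16 log units; within the scatter), replaces the whole group at that position and stays within the scatter.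

Compound 4 `COc1cccc(/C=C/C(=O)/C=C/c2ccc(OCc3cn(CCOc4cc(=O)oc5ccccc45)nn3)c(OC)c2)c1` differs from compound 1 by 3-methoxyphenyl in place of 2-methoxyphenyl on a double-bonded chain carbon bound to a double-bonded chain carbon. Among the measured compounds shown here, the step from compound 1 to compound 3 is the one measurement that bears on this position: a larger replacement of the group there left the number essentially unchanged. For the measured compounds named here, no measured step alters only the placement of a methoxy group on this ring, so that part of the change is untested. The expectation therefore rests on compound 1 and its value 9490 nM and on the small step seen in a 1.5-fold lower number from compound 1 to compound 3 (0.16 log units; within the scatter), and is for no movement beyond the scatter.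

Compound 4 is expected to give about 9000 nM in this assay, with a range from 4500 nM to 18000 nM. The expected step is a 1.1-fold lower number from compound 1 to compound 4 (0.02 log units; within the scatter).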

Compound 4, half-maximal inhibitory concentration: 9760 nM
Compound 4: middle estimate off by 1.1-fold (0.04 log units), on the low side; the measured number falls inside the stated range.
By their numbers in this assay, from the lowest: compounds 3, 2, 1 and 4 (each within the scatter of the next).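

Among these compounds, changing 2-methoxyphenyl to 3-methoxyphenyl on a double-bonded chain carbon bound to a double-bonded chain carbon tests the placement of the methoxy group directly for the first time, and this assay gives a 1.0-fold higher number from compound 1 to compound 4 (0.01 log units; within the scatter) with no separation of the two compounds on this read-out. The comparison with the larger aromatic group gives a 1.5-fold higher number from compound 3 to compound 4 (0.17 log units; within the scatter) and also stays within the scatter, so 2-methoxyphenyl, 3-methoxyphenyl and naphthalen-1-yl cannot be told apart at this position in the compounds shown. No measurement at hand offers an explanation for this flat result.

From the compounds shown here alone, whether a group of another kind at this place, such as an amine or a carboxylic acid on the ring, would move the number beyond the scatter remains open. Also open, going by these compounds, is whether 4-methoxyphenyl, or a fluorine atom on the same ring, would leave the number as undisturbed as 3-methoxyphenyl does.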